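A few compounds are considered here, and "the series" means these few. Any claim that something is new, unique, unknown or untested is made for them only; others in the source may bear on it.

For the measured compounds named here, in a functional assay on MCF7 cells (Homo sapiens) for antiproliferative activity, read by MTT assay, with a stated time of 24 h (on this read-out higher numbers stand for weaker inhibition and lower numbers for stronger inhibition), only two compounds built on the shared core have been measured so far. Compound 1 `CCn1c(C(=O)NCCNC(=O)OC(C)(C)C)ccc1C(CC)(CC)c1ccc(OCS(=O)(=O)c2ccccc2)c(C)c1` gives > 50000 nM, which is a limit of the assay and not a number. Going by the values given here, compound 2 `CCn1c(C(=O)NCCO)ccc1C(CC)(CC)c1ccc(OCS(=O)(=O)c2ccccc2)c(C)c1` gives 15500 nM, the only actual number available. Among the compounds with values here, the one measured step is an at least 3.2-fold lower number from compound 1 to compound 2 (0.50 log units; beyond the scatter), with hydroxy in place of (tert-butoxycarbonyl)amino. Compound 3 `CCn1c(C(=O)NC(C)(C)CO)ccc1C(CC)(CC)c1ccc(OCS(=O)(=O)c2ccccc2)c(C)c1` keeps that hydroxy and differs from compound 2 on the amide-type nitrogen: 1-(hydroxymethyl)-1-methylethyl in place of 2-hydroxyethyl on an amide-type nitrogen. The earlier step exchanged a different group and rests on a limit, so it bears on this change only indirectly. Going by these compounds, no shift beyond the scatter is therefore expected in this assay, and the direction remains open. The expected result is a 1.0-fold higher number from compound 2 to compound 3 (0.01 log units; within the scatter). For compound 3 the estimated value is 16000 nM, with an expected range from 6000 nM to 45000 nM.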

Compound 3, half-maximal inhibitory concentration: 20700 nM
Compound 3: the middle estimate sits 1.3-fold (0.11 log units) below what was measured; the range from low to high includes it.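

In this assay, replacing 2-hydroxyethyl with 1-(hydroxymethyl)-1-methylethyl on the amide-type nitrogen gives a 1.3-fold higher number from compound 2 to compound 3 (0.13 log units; within the scatter), so a group of 5 heavy atoms in place of 3, with the hydroxy kept, moves the number by no more than the scatter. The lower number first seen with a hydroxy-bearing group recurs with this second one, at an at least 2.4-fold lower number from compound 1 to compound 3 (0.38 log units; beyond the scatter). Compound 1 remains a limit and not a number, so the size of that step stays bounded on one side only: the limit of > 50000 nM in this assay, at which 1 of the 3 values shown sits.

Going by these compounds, what a primary amine or a carboxylic acid in place of the hydroxy would do remains open, as does the effect of a longer chain on the amide-type nitrogen. Also open, on these data alone, is whether any group here can bring the number well under that of compound 2, at 15500 nM.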